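The compounds below may be only part of what the source reports. "The series", "measured", "known", "first", "only" and "open" are said of these compounds alone.

Two ureas on the shared core have been run through a functional assay on PC-3 cells (Homo sapiens) for inhibition, read by sulforhodamine B assay, with a stated time of 48 h; a higher number here means that more compound is tolerated, a lower number that less compound is tolerated. Compound 1 `COc1cc(-c2nn(-c3cccc(NC(=O)Nc4ccc(Cl)c(Cl)c4)c3)cc2-c2ccncc2)ccc1Cl` returns only a limit of the assay, > 50000 nM, not a number. Compound 2 `COc1cc(-c2nn(-c3cccc(NC(=O)Nc4cccc(C(F)(F)F)c4)c3)cc2-c2ccncc2)ccc1Cl` likewise returns a limit, > 50000 nM, again not a number. Within the data shown here, the one step measured so far, a step that the two limits leave unreadable from compound 1 to compound 2, cannot be read for size, since both ends are limits; the standing of compound 2 is therefore only that it sits at the limit of > 50000 nM in this assay, at which 2 of the 2 values shown sit, together with compound 1.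

Compound 3 `COc1cc(-c2nn(-c3cccc(NC(=O)c4ccccc4)c3)cc2-c2ccncc2)ccc1Cl` is not yet measured. The change from compound 2 is phenyl in place of (3-(trifluoromethyl)phenyl)amino on a carbonyl carbon, that is, the urea becomes a benzamide. No measured step covers this kind of change, and the only step shown is unreadable, so nothing here points to a shift in either direction beyond the scatter. Compound 3 is expected to remain at the limit as well, with an estimated step of a number no higher from compound 2 to compound 3 (the limit leaves the size open) of no readable size. The estimate for compound 3 in this assay is 50000 nM, with a range from 20000 nM to 50000 nM.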

Compound 3, concentration lethal to 50% of the cells: > 100000 nM
Compound 3: no number, only a limit (the forecaster's own chance of this, stated with the estimate: 75%); at least 2.0-fold (0.30 log units) between middle value and limit.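

In this assay, compound 1, compound 2 and compound 3 all return limits of the assay, not numbers, so none of the steps among them can be read for size. On these data alone, what stays open is where any of the three would give an actual value, and whether replacing the urea with the benzamide changes it at all.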